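Swapping methoxy for chloro on compound 2

The compounds below may be only part of what the source reports. "The series", "measured", "known", "first", "only" and "open" are said of these compounds alone.

Measured in a functional assay on MDA-MB-231 cells (Homo sapiens) for antiproliferative activity, read by CellTiter-Glo, with a stated time of 96 h; a lower number here means a stronger inhibitor, a higher number a weaker inhibitor:
Compound 1 `COc1ccc(-c2nsc3c2NC(=O)CC3c2cccc(F)c2)cc1`: > 2000 nM
Compound 2 `COc1ccc(-c2nsc3c2NC(=O)CC3c2ccsc2)cc1`: 192 nM

The entry for compound 1, > 2000 nM, is a limit and not a number. Going by the values given here, compound 2, at 192 nM, therefore holds the only true number so far. Compound 3 `O=C1CC(c2ccsc2)c2snc(-c3ccc(Cl)cc3)c2N1` differs from compound 2 in one place: chloro in place of methoxy on an aromatic carbon. Among the compounds with values here, the one measured step, an at least 10-fold lower number from compound 1 to compound 2 (1.01 log units; beyond the scatter), is large, but it changes the group on a saturated ring carbon and leaves the methoxy untouched. Within the data shown here, it shows that a single swap can move the number a long way, yet no measured step covers chloro in place of methoxy. A modest change in this assay with no firm direction is therefore expected, and the step expected is a 1.3-fold higher number from compound 2 to compound 3 (0.11 log units; within the scatter). For compound 3 the estimate is 250 nM, with an expected range of 70 nM to 1000 nM.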

Compound 3, half-maximal inhibitory concentration: 1630 nM
The estimate for compound 3 lay 6.5-fold (0.81 log units) below the measured number, outside the stated range (above it).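

Chloro in place of methoxy gives an 8.5-fold higher number from compound 2 to compound 3 (0.93 log units; beyond the scatter) in this assay and so shows that this aromatic carbon, para to a large group, is also a place where a single swap moves the number beyond the scatter. The change takes away two heavy atoms with one hydrogen-bond acceptor and brings in one chlorine atom with none, but this single pair cannot tell which of these differences matters. Compound 3 still gives a true number and not a limit, and the assay does have a limit: the limit of > 2000 nM in this assay, at which 1 of the 3 values shown sits.

Going by these compounds, it remains open how a hydroxyl, an amine or a plain methyl on this carbon would read. On these data alone, it is also open whether the same swap would give a step of similar size with a group other than thiophen-3-yl on the saturated ring carbon.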